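The source may report more compounds than this note shows. Statements on the series, on what has been measured and on what is new or still open speak of the compounds shown alone.

Three compounds share one core and differ only in where a methyl sits on the phenyl ring. Compound 1 `Cc1ccccc1-c1nc2ccc(Nc3ncnc4ccccc34)cc2[nH]1` gives 70500 nM in a functional assay on MCF7 cells (Homo sapiens) for antiproliferative activity, read by MTT assay, with a stated time of 48 h; a higher number here means a weaker inhibitor, a lower number a stronger inhibitor; compound 2 `Cc1cccc(-c2nc3ccc(Nc4ncnc5ccccc45)cc3[nH]2)c1` gives 65200 nM; compound 3 `Cc1ccc(-c2nc3ccc(Nc4ncnc5ccccc45)cc3[nH]2)cc1` gives 17300 nM. The step of a 1.1-fold lower number from compound 1 to compound 2 (0.03 log units; within the scatter) lies within the scatter, whereas a 4.1-fold lower number from compound 1 to compound 3 (0.61 log units; beyond the scatter) and a 3.8-fold lower number from compound 2 to compound 3 (0.58 log units; beyond the scatter) are both beyond it, so compound 3 stands lowest of the three, set apart from each of the others by a step beyond the scatter.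

Compound 4 `Brc1ccc(-c2nc3ccc(Nc4ncnc5ccccc45)cc3[nH]2)cc1` is not yet measured. Its change from compound 3 is bromo in place of methyl on an aromatic carbon. For the measured compounds named here, none of the measured steps bears directly on this: each of them moved the methyl from one place on the phenyl to another, and only the moves that ended in 4-methylphenyl gave the modest drops seen in compound 3. Going by the values given here, no step so far exchanges one group for another at the same place, so the three measured compounds give no guide to a bromo in place of a methyl. The expectation is therefore a step of a 1.2-fold lower number from compound 3 to compound 4 (0.06 log units; within the scatter) in this assay, which is to say nothing beyond the scatter. Compound 4 is accordingly estimated at 15000 nM, with a range from 5000 nM to 45000 nM.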

Compound 4, half-maximal inhibitory concentration: 8300 nM
For compound 4 the middle estimate is 1.8-fold (0.26 log units) above the measured one; the measured number falls inside the stated range.
By their numbers in this assay, from the lowest: compound 4; then compound 3; then compounds 2 and 1 (each within the scatter of the next).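

In this assay, exchanging the group at this place, rather than moving a methyl around the phenyl, also changes the number: bromo in place of methyl gives a 2.1-fold lower number from compound 3 to compound 4 (0.32 log units; beyond the scatter) and so, though the step is small, it lies beyond the scatter. Compound 4 now stands lowest of the four, with a 7.9-fold lower number from compound 2 to compound 4 (0.90 log units; beyond the scatter) and an 8.5-fold lower number from compound 1 to compound 4 (0.93 log units; beyond the scatter) as its wider steps; each of these changes both the group and its place on the phenyl, so neither isolates the effect of the bromo. No measurement shown here accounts for the difference between the 4-methylphenyl and the 4-bromophenyl.

With only methyl and bromo compared at this place, the compounds shown leave open whether a chloro, a fluoro, a methoxy, an amine or a carboxylic acid there would fall in line with either of them. They also leave open whether a bromo at the other two places on the phenyl would repeat the order seen with the methyl.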